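The source may report more compounds than this note shows. Statements on the series, on what has been measured and on what is new or still open speak of the compounds shown alone.

Compound 1, `COc1ccc(/C=C\c2cc(OC)c(OC)c(OC)c2)cc1OCc1ccc(CN2CCCC[C@H]2C(=O)O)cc1`, was tested in an ADME assay on HEK293 cells (Homo sapiens) for cytotoxicity, read by CCK-8 assay, with a stated time of 48 h; on this read-out higher numbers stand for weaker inhibition and lower numbers for stronger inhibition. Here compound 1 gives > 50000 nM, which is a limit of the assay rather than a measured number. So compound 1 stands only at a limit among the three values in hand, and the limit of > 50000 nM in this assay, at which 2 of the 3 values shown sit, shows how common that outcome is in this small set.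

Compound 2, `COc1ccc(/C=C\c2cc(OC)c(OC)c(OC)c2)cc1OCc1ccc(CN2CC(C(=O)O)C2)cc1`, gives > 50000 nM in this assay, again a limit. Going by the values given here, compound 3, `COc1ccc(/C=C\c2cc(OC)c(OC)c(OC)c2)cc1OCc1ccc(CNCCN(C)C)cc1`, is the one compound with a read number, 39000 nM in this assay. The step that the two limits leave unreadable from compound 1 to compound 2 therefore cannot be sized; the steps of an at least 1.2-fold lower number from compound 1 to compound 3 (0.10 log units; that floor lies within the scatter) and an at least 1.2-fold lower number from compound 2 to compound 3 (0.10 log units; that floor lies within the scatter) are both floors that fall inside the ordinary scatter of this assay.

Compound 4, `COc1ccc(/C=C\c2cc(OC)c(OC)c(OC)c2)cc1OCc1ccc(CN2CC[C@@H](O)C2)cc1`, is not yet measured. Relative to compound 1 the change is 3-hydroxypyrrolidin-1-yl in place of 2-carboxypiperidin-1-yl on a saturated chain carbon bound to an aromatic carbon. The step from compound 1 to compound 2, a swap of one carboxy-bearing ring for another, left the value at the limit, and the step to compound 3, a larger change to an open-chain amine, moved the number only by a floor within the scatter. Nothing here points to a readable step, so compound 4 is expected to stay near the limit, with an estimated step of a number no higher from compound 1 to compound 4 (the limit leaves the size open). The expected value for compound 4 is 50000 nM, within a range of 30000 nM to 100000 nM.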

Compound 4, half-maximal inhibitory concentration: > 50000 nM
Compound 4: a limit, no number; the forecaster's own chance of this, stated with the estimate: 70%; the middle value lies on the limit itself.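

In compound 4 the carboxy-bearing ring gives way, on a saturated chain carbon bound to an aromatic carbon, to 3-hydroxypyrrolidin-1-yl, a five-membered ring with a hydroxy group, and in this assay compound 4 gives > 50000 nM, which is a limit of the assay. Going by these compounds alone, compound 1 and compound 2 both carry a carboxy group on their rings, so they could not show what this result adds, that a ring with a hydroxy group in its place also ends at the limit, now the most frequent outcome in this small set: the limit of > 50000 nM in this assay, at which 3 of the 4 values shown sit. Against the open-chain (2-(dimethylamino)ethyl)amino group the only readable comparison is an at least 1.2-fold higher number from compound 3 to compound 4 (0.10 log units; that floor lies within the scatter), while the steps that link compound 4 with compound 1 and compound 2 join two limits and cannot be read.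

Going by these compounds, it remains open whether a piperazine or morpholine ring, or a longer chain ending in an amine, would give a read number clearly lower than the limit at this place. With a single read number in this assay, 39000 nM for compound 3, the groups shown cannot yet be ranked.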